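Moving a methyl on the benzylic ring of compound 1

The source may report more compounds than this note shows. Statements on the series, on what has been measured and on what is new or still open speak of the compounds shown alone.

Of the compounds shown here, two have been tested in a functional assay on HeLa cells (Homo sapiens) for cytotoxicity, read by MTT assay, with a stated time of 72 h; on this read-out lower numbers stand for stronger inhibition and higher numbers for weaker inhibition. Compound 1, `Cc1ccc(CSc2cc(Cl)c(C)cc2S(=O)(=O)/N=C(\N)n2nc(C)cc2-c2ccccc2)cc1`, gives 62000 nM in this assay, the higher of the two numbers recorded. Compound 2, `Cc1cc(S(=O)(=O)/N=C(\N)n2nccc2-c2ccccc2)c(SCc2ccccc2)cc1Cl`, gives 5000 nM in this assay; the two structures differ in more than one place, so only the two numbers themselves can be compared, and they lie well apart.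

Compound 3, `Cc1cc(-c2ccccc2)n(/C(N)=N/S(=O)(=O)c2cc(C)c(Cl)cc2SCc2ccccc2C)n1`, is built from compound 1 by a single rearrangement: 2-methylphenyl in place of 4-methylphenyl on a saturated chain carbon bound to a sulfur. Among the compounds with values here, no measured pair shows what such a move does here. With the same atoms kept and only their arrangement changed, the expectation for compound 3 is a number close to that of compound 1, with the step of a 1.1-fold lower number from compound 1 to compound 3 (0.05 log units; within the scatter) expected to stay within the ordinary scatter. Compound 3 is therefore estimated at 55000 nM in this assay, within a range from 20000 nM to 150000 nM.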

Compound 3, half-maximal inhibitory concentration: 160000 nM
Estimate against measurement, compound 3: 2.9-fold (0.46 log units) below, outside the stated range (above it).
By their numbers in this assay, from the lowest: compound 2; then compound 1; then compound 3.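

In this assay the change from 4-methylphenyl to 2-methylphenyl gives a 2.6-fold higher number from compound 1 to compound 3 (0.41 log units; beyond the scatter) even though every atom is kept and only the place of one methyl on the ring differs. This shows that the group on the saturated chain carbon bound to a sulfur is sensitive to how it is arranged, and here the 2-methylphenyl arrangement goes with weaker inhibition; compound 1 and compound 2 differ in more than one place, so they could not show this. No measurement at hand explains why this rearrangement has this effect.

This single step leaves open how a 2-chlorophenyl or a 4-methoxyphenyl group would behave at this place. It also cannot tell whether the same move of the methyl would give a similar step on the core of compound 2.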